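Trimming a Side Chain: Expected Solubility of Compound 4

The source may hold more compounds than are shown below. What is called first, only, known or untested is meant among the compounds shown, and "the series" means these compounds.

Measured compounds:
compound 1 `CC(C)C(NC(=O)c1ccc(C#Cc2ccccc2)cc1)C(=O)NO` gives 7000 nM
compound 2 `O=C(NC1(C(=O)NO)CCCCC1)c1ccc(C#Cc2ccccc2)cc1` gives < 1000 nM
compound 3 `O=C(NC1(C(=O)NO)CCN(Cc2ccccc2)CC1)c1ccc(C#Cc2ccccc2)cc1` gives < 1000 nM

Of the compounds shown here, three sharing the same core have been tested in a physicochemical assay for solubility; on this read-out higher numbers stand for higher solubility and lower numbers for lower solubility. Compound 1 gives 7000 nM in this assay, and it is the only one of the three with an actual number. For compound 2 the result of < 1000 nM is a limit of the assay rather than a number. For compound 3 the result of < 1000 nM is likewise a limit. So compound 1 stands alone at the top of what is shown, with the other two sitting at the limit of < 1000 nM in this assay, at which 2 of the 3 values shown sit.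

Compound 4 `CC(C)(NC(=O)c1ccc(C#Cc2ccccc2)cc1)C(=O)NO` has not yet been measured. It differs from compound 1 in one place: 1-(hydroxycarbamoyl)-1-methylethyl in place of 1-(hydroxycarbamoyl)-2-methylpropyl on an amide-type nitrogen. The group that enters is one heavy atom smaller than the one that leaves, with the same count of hydrogen-bond donors and acceptors, and no ring is gained or lost.

Among the measured compounds shown here, no measured step between two compounds is available to guide the size of this change, so the expectation rests on compound 1 and the nature of the swap. A small step is expected, if any, within the usual scatter of repeated measurements. Compound 4 is therefore estimated at 8000 nM, with a range from 3500 nM to 18000 nM. The step this means, a 1.1-fold higher number from compound 1 to compound 4 (0.06 log units; within the scatter), is expected to be small.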

Compound 4, solubility: 182000 nM
Estimate against measurement, compound 4: 23-fold (1.36 log units) below; the whole stated range lies below it.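

This place on the amide-type nitrogen turns out to be highly sensitive in this assay: replacing 1-(hydroxycarbamoyl)-2-methylpropyl with 1-(hydroxycarbamoyl)-1-methylethyl gives a 26-fold higher number from compound 1 to compound 4 (1.41 log units; beyond the scatter). The earlier compounds shown here offered no pair differing in one place, so they could not show how much a single change here can matter. This swap looks minor on paper, going from 8 heavy atoms to 7 with the same counts of hydrogen-bond donors and acceptors and no ring gained or lost, yet nothing shown here explains the size of this step.

Going by these compounds, this is a single step, so it sets no trend, and it remains unknown whether other groups at this place would move the read-out as far. The compounds shown also leave open how a side chain ending in an amine or a carboxylic acid, or a longer chain, would behave in this assay, which would help show whether compound 4 is an isolated case or part of a wider pattern.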